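Urea to amide at the carbonyl: working notes

The source may hold more compounds than are shown below. What is called first, only, known or untested is meant among the compounds shown, and "the series" means these compounds.

Measured compounds:
compound 1 `O=C(Nc1cccc(-n2cc(-c3ccncc3)c(-c3cc(O)cc(Cl)c3)n2)c1)Nc1ccc(Cl)c(C(F)(F)F)c1` — -55%
compound 2 `COc1cc(Cl)cc(-c2nn(-c3cccc(NC(=O)Nc4ccc(Cl)c(C(F)(F)F)c4)c3)cc2-c2ccncc2)c1` — -50%
compound 3 `COc1cc(Cl)cc(-c2nn(-c3cccc(NC(=O)Nc4cc(C(F)(F)F)cc(C(F)(F)F)c4)c3)cc2-c2ccncc2)c1` — -58%

In a functional assay on NCI-H23 cells (Homo sapiens) for inhibition, read by sulforhodamine B assay, with a stated time of 48 h, tested at 100 uM (a lower number here means a stronger effect, a higher number a weaker effect of the compound at the concentration tested), compound 1 gives -55%, compound 2 gives -50% and compound 3 gives -58%. Compound 2 stands highest of the three numbers, yet its gap to compound 1 and its gap to compound 3 are both within the scatter, so no order among the three is supported. Within the data shown here, the single measured step, a number 5 percentage points higher from compound 1 to compound 2 (within the scatter), concerns the methyl in place of hydrogen on an oxygen and lies within the scatter. Compound 2 and compound 3 differ on the aryl attached to the urea nitrogen; their two values sit within the scatter of each other, and nothing more can be read from that pair.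

Compound 4 `COc1cc(Cl)cc(-c2nn(-c3cccc(NC(=O)c4cccc(C(F)(F)F)c4)c3)cc2-c2ccncc2)c1` differs from compound 2 as follows: 3-(trifluoromethyl)phenyl in place of (4-chloro-3-(trifluoromethyl)phenyl)amino on a carbonyl carbon. Among the measured compounds shown here, no measured step touches the carbonyl carbon or removes a nitrogen from the urea, so there is no precedent for this change; the only comparisons available concern other positions and stayed within the scatter. The step is therefore expected to be a number 15 percentage points higher from compound 2 to compound 4 (beyond the scatter), with wide uncertainty because no shown step bears on it. Compound 4 is estimated at -35%, expected to fall between -75% and 10%.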

Compound 4, a percentage reported as activity, at one concentration (the size of the read-out at that concentration, not a potency): 27%
For compound 4 the middle estimate is 62 percentage points below the measured one, outside the stated range (above it).
By their numbers in this assay, from the lowest: compounds 3, 1 and 2 (each within the scatter of the next); then compound 4.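

Working notes on the carbonyl position: in this assay the replacement on the carbonyl carbon gives a number 77 percentage points higher from compound 2 to compound 4 (beyond the scatter) and is the only step shown that lies beyond the scatter, whereas the changes on the oxygen and on the aryl attached to the urea nitrogen left compounds 1, 2 and 3 within the scatter of one another. This makes the group on the carbonyl carbon the one place in the compounds shown where the read-out responds strongly, and the sign of the read-out differs as well, with compound 2 at -50% and compound 4 at 27%. The change is a combined one, since the amino nitrogen with its hydrogen-bond donor leaves together with the chlorine, and no available data explain the size of the step or divide it between those two parts.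

The compounds shown leave open whether the nitrogen or the chlorine carries the step, a question that an amide bearing 4-chloro-3-(trifluoromethyl)phenyl on the carbonyl carbon would address directly. Also open, as far as these compounds go, is how a methylene group in place of the amino nitrogen, or a methyl group on that nitrogen, would read.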